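A few compounds are considered here, and "the series" means these few. Any claim that something is new, unique, unknown or untested is made for them only; others in the source may bear on it.

Of the compounds shown here, three have been measured in a functional assay on the whole organism for inhibition, with Rattus norvegicus as the target, read by paw edema, with stated times of 30 min and 3 h, at a dose of 0.28 mmol/kg by the oral route; a lower number here means less inhibition, a higher number more inhibition at the dose given (going by the name of the read-out). Compound 1 `COc1ccc(-n2nc(C(N)=O)nc2-c2cc(OC)c(OC)c(OC)c2)cc1` gives 92%; compound 2 `CNC(=O)c1nc(-c2cc(OC)c(OC)c(OC)c2)n(-c2ccc(OC)cc2)n1` gives 95%; compound 3 `COc1ccc(-n2nc(C(=O)Nc3ccccc3C)nc2-c2cc(OC)c(OC)c(OC)c2)cc1` gives 64%. Compound 3 stands lowest of the three: a number 28 percentage points lower from compound 1 to compound 3 (beyond the scatter) and a number 31 percentage points lower from compound 2 to compound 3 (beyond the scatter), both beyond the scatter, whereas a number 3 percentage points higher from compound 1 to compound 2 (within the scatter) lies within it.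

The next compound, compound 4 `COc1ccc(-n2nc(C(=O)Nc3ccc(O)cc3)nc2-c2cc(OC)c(OC)c(OC)c2)cc1`, has not yet been measured. The change is 4-hydroxyphenyl in place of 2-methylphenyl on an amide-type nitrogen. Among the measured compounds shown here, both measured steps that reach compound 3 put 2-methylphenyl in place of hydrogen or methyl on the amide-type nitrogen and lower the read-out; neither step compares one aryl group with another, so no measured step bears directly on this change. Compound 4 keeps an aryl group on the amide-type nitrogen, and its read-out in this assay is therefore expected to stay near that of compound 3, a number 1 percentage points higher from compound 3 to compound 4 (within the scatter), with no step beyond the scatter foreseen in either direction. For compound 4 the estimate is 65%, within 45% to 85%.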

Compound 4, a percentage reported as inhibition, in the whole organism at one dose (the size of the read-out at that dose, not a potency): 64%
For compound 4 the middle estimate is 1 percentage points above the measured one, within the range that was stated.
By their numbers in this assay, from the lowest: compounds 3 and 4 (each within the scatter of the next); then compounds 1 and 2 (each within the scatter of the next).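

In this assay, among the compounds shown here, the first comparison of one aryl group with another on the amide-type nitrogen gives no change at the digits printed from compound 3 to compound 4 (within the scatter), so this position does not separate 4-hydroxyphenyl from 2-methylphenyl, even though only the former carries a hydrogen-bond donor and acceptor. The lower read-out also recurs with a second aryl group, with a number 31 percentage points lower from compound 2 to compound 4 (beyond the scatter) and a number 28 percentage points lower from compound 1 to compound 4 (beyond the scatter), so it is not confined to 2-methylphenyl. No available evidence bears on this result.

Two substituted phenyl groups cannot show whether the lower read-out extends to aryl groups in general, and unsubstituted phenyl or a pyridyl ring on this nitrogen would test that. A benzyl group or a longer chain such as butyl could show how the read-out behaves between methyl and the aryl groups.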